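A few compounds are considered here, and "the series" means these few. Any claim that something is new, unique, unknown or untested is made for them only; others in the source may bear on it.

Measured so far:
- compound 1, `COc1cc2ncnc(NNC(=S)NC(=O)c3ccc(C(F)(F)F)cc3)c2cc1OC`: 16500 nM
- compound 2, `COc1cc2ncnc(NNC(=S)NC(=O)c3ccccc3C)c2cc1OC`: 10500 nM
- compound 3, `Cc1ccc(C(=O)NC(=S)NNc2ncnc3ccccc23)cc1`: 17200 nM

All three were tested in a functional assay on CNE-2 cells (Homo sapiens) for cytotoxicity, read by MTT assay, with a stated time of 72 h; on this read-out higher numbers stand for weaker inhibition and lower numbers for stronger inhibition. Compound 2 gives the lowest of the three numbers, yet neither neighbour is clearly apart from it: the step of a 1.6-fold lower number from compound 1 to compound 2 (0.20 log units; within the scatter) lies within the scatter, and the value of compound 3 also sits close to that of compound 2. The new compound is compound 4, `COc1cc2ncnc(NNC(=S)NC(=O)c3ccccc3)c2cc1OC`, which differs from compound 2 in one place: hydrogen in place of methyl on an aromatic carbon. Going by the values given here, the only measured step that touches the same region, the group on the carbonyl carbon, is a 1.6-fold lower number from compound 1 to compound 2 (0.20 log units; within the scatter), where a rather different aryl group was swapped in and the number barely moved. Among the compounds with values here, nothing measured so far speaks for a large effect from trimming a single methyl on that ring. Compound 4 is therefore expected to show a 1.1-fold higher number from compound 2 to compound 4 (0.06 log units; within the scatter), a step within the scatter. The estimate for compound 4 is 12000 nM, with a range from 6000 nM to 25000 nM.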

Compound 4, half-maximal inhibitory concentration: 8180 nM
Compound 4: middle estimate off by 1.5-fold (0.17 log units), on the high side; low and high end bracket the measured number.
By their numbers in this assay, from the lowest: compounds 4, 2, 1 and 3 (each within the scatter of the next, the first and the last beyond it).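

Taking the methyl off the ring gives a 1.3-fold lower number from compound 2 to compound 4 (0.11 log units; within the scatter), so in this assay the 2-methylphenyl and phenyl compounds cannot be told apart. Every earlier compound carried a group on this ring, whereas compound 4 carries none and provides the first unsubstituted comparison. Replacing trifluoromethyl with hydrogen gives a 2.0-fold lower number from compound 1 to compound 4 (0.30 log units; within the scatter), so neither the methyl of compound 2 nor the trifluoromethyl of compound 1 is needed to keep the number in this range.

Still open, on these data alone, is whether a different group on this ring, such as an amine or a carboxylic acid, would give a step beyond the scatter. No independent measurement is available to explain the size of these steps.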